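The compounds below may be only part of what the source reports. "The series", "measured", "known", "first", "only" and "open" are said of these compounds alone.

Of the compounds shown here, three of a shared core have been measured in a functional assay on the whole organism (strain CF-1) for inhibition, with Mus musculus as the target; a higher number here means that more compound is needed for the effect, a lower number that less compound is needed. Compound 1, `Cc1nnc(CN(C)C)n1-c1ccc(Cl)cc1C(=O)c1ccccc1`, gives 0.5 mg/kg. Compound 2, `Cc1nnc(CN(C)C)n1-c1ccccc1C(=O)c1ccccc1Cl`, gives 5 mg/kg. Compound 3, `Cc1nnc(CN2CCCC2)n1-c1ccc(Cl)cc1C(=O)c1ccccc1Cl`, gives 1.3 mg/kg, which places it second highest of the three numbers; its nearest neighbour is compound 1, whose number is lower by a margin beyond the usual scatter, and its furthest is compound 2, whose number is higher, again beyond the scatter. No pair among these three differs in a single place, so no isolated step can be read from the measured set.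

Compound 4, `Cc1nnc(CN(C)C)n1-c1ccc(Cl)cc1C(=O)c1ccccc1Cl`, has not yet been measured. It differs from compound 3 in one place: dimethylamino in place of pyrrolidin-1-yl on a saturated chain carbon bound to an aromatic carbon. This brings the amine of compound 4 into line with that of compound 1 and compound 2, while the rest of the molecule stays as in compound 3. Among the measured compounds shown here, since no measured pair isolates this particular exchange, its size cannot be taken from the data. The amine change is expected to move the number little, if at all, beyond the scatter, with compound 4 expected to sit close to compound 3 because compound 3 gives 1.3 mg/kg. Compound 4 is therefore expected to give about 1 mg/kg in this assay, within a range from 0.4 mg/kg to 2.5 mg/kg, a step of a 1.3-fold lower number from compound 3 to compound 4 (0.11 log units; within the scatter).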

Compound 4, dose for half-maximal effect: 0.14 mg/kg
Beside the measured number, compound 4's estimate is 7.1-fold (0.85 log units) above it; the whole stated range lies above it.
By their numbers in this assay, from the lowest: compound 4; then compound 1; then compound 3; then compound 2.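

In this assay, among the compounds shown here, the exchange of pyrrolidin-1-yl for dimethylamino on a saturated chain carbon bound to an aromatic carbon, which no earlier pair isolated, proves to matter, giving a 9.3-fold lower number from compound 3 to compound 4 (0.97 log units; beyond the scatter). For the compounds shown here, compound 4 also allows each chloro in place of hydrogen on an aromatic carbon to be read alone: the one absent from compound 2 gives a 36-fold lower number from compound 2 to compound 4 (1.55 log units; beyond the scatter), and the one absent from compound 1 gives a 3.6-fold lower number from compound 1 to compound 4 (0.55 log units; beyond the scatter). Each chloro therefore goes with a lower number, the first in a large step and the second in a modest one, and compound 4 has the lowest number of the four, with its steps to all the others beyond the scatter.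

Nothing available explains the size of these steps. The compounds shown leave open where amines such as diethylamino or piperidin-1-yl would fall relative to dimethylamino and pyrrolidin-1-yl, and whether fluoro or bromo in place of either chloro would give a similar lowering of the number.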